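Phenyl for pyridin-2-yl: notes toward compound 4

A few compounds are considered here, and "the series" means these few. Any claim that something is new, unique, unknown or untested is made for them only; others in the source may bear on it.

Measured so far in a functional assay on DU-145 cells (Homo sapiens) for cytotoxicity, read by CCK-8 assay and cell counting, with a stated time of 2 days; on this read-out lower numbers stand for stronger inhibition and higher numbers for weaker inhibition: compound 1 `Oc1cccc(-c2cc(-c3ccc(Cl)cc3)nc(-c3ccccn3)c2)c1` gives 8090 nM; compound 2 `Oc1cccc(-c2cc(-c3ccccc3)nc(-c3ccc(Cl)cc3)c2)c1` gives 11200 nM; compound 3 `Oc1cccc(-c2cc(-c3ccccn3)nc(-c3ccccc3Cl)c2)c1` gives "not determined" (no result reported), that is, no result reported.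

The step of a 1.4-fold higher number from compound 1 to compound 2 (0.14 log units; within the scatter) comes from phenyl in place of pyridin-2-yl on an aromatic carbon. Compound 4 `Oc1cccc(-c2cc(-c3ccccc3)nc(-c3ccccc3Cl)c2)c1` is not yet measured and stands to compound 3 as compound 2 stands to compound 1, through (phenyl in place of pyridin-2-yl on an aromatic carbon). The two cores differ by 2-chlorophenyl in place of 4-chlorophenyl on an aromatic carbon. Around the place the surroundings read meta to a 2-chlorophenyl group in compound 3 against meta to a 4-chlorophenyl group in compound 1, so the two changes are the same kind of change, not the same. Compound 3 gives no number, so nothing anchors compound 4 on it. In this assay the step expected for the pair compound 3 and compound 4 is of the same kind. Its size is expected to be that of a 1.4-fold higher number from compound 1 to compound 2 (0.14 log units; within the scatter), within the scatter. Because compound 2 gives 11200 nM, compound 4 is expected near 12000 nM, from 5000 nM to 30000 nM.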

Compound 4, half-maximal inhibitory concentration: 1480 nM
Beside the measured number, compound 4's estimate is 8.1-fold (0.91 log units) above it; measured number below the stated range.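

In this assay, going by these compounds alone, the only step that can be read on the 2-chlorophenyl core is a 7.6-fold lower number from compound 2 to compound 4 (0.88 log units; beyond the scatter), and it comes from 2-chlorophenyl in place of 4-chlorophenyl, with phenyl on both sides. Compound 3 has no reported result, so the step for phenyl in place of pyridin-2-yl cannot be read on this core; whether a 1.4-fold higher number from compound 1 to compound 2 (0.14 log units; within the scatter) carries over, and whether the chlorophenyl step holds with pyridin-2-yl present, stays unanswered. Nothing at hand accounts for the size of the new step.

Open, as far as these compounds go, is whether the step is specific to chlorine, which a 2-fluorophenyl or 2-methoxyphenyl group would test. The 3-hydroxyphenyl group is also constant throughout, so a 3-aminophenyl group or a carboxylic acid there remains an open question.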